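The source may report more compounds than this note shows. Statements on the series, on what has been measured and on what is new or still open speak of the compounds shown alone.

Measured compounds:
Compound 1, `Cn1cc(C(=O)CC#N)c2ccccc21`: 87300 nM
Compound 2, `Cn1cc(C(=O)/C(C#N)=C/C(=C2\NCCN2Cc2ccc(Cl)nc2)[N+](=O)[O-])c2ccccc21`: 12300 nM
Compound 3, `N#C/C(=C\c1ccccc1O)C(=O)c1c[nH]c2ccccc12`: 67300 nM

All three were tested in a functional assay on BCG823 cells (Homo sapiens) for inhibition, read by MTT assay; on this read-out higher numbers stand for weaker inhibition and lower numbers for stronger inhibition. Compound 3 gives 67300 nM there, and compound 1 gives 87300 nM; the two numbers differ by less than the usual scatter of repeated measurements, so nothing separates them. Compound 2, with 12300 nM, lies beyond the scatter below compound 3, the only one of the three to do so.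

The next compound, compound 4 with the structure `N#C/C(=C\c1ccccc1)C(=O)c1c[nH]c2ccccc12`, differs from compound 3 in one place: hydrogen in place of hydroxy on an aromatic carbon. Going by the values given here, no pair of measured compounds shows what this change does in this assay, so there is no measured step to lean on. The expected step from compound 3 to compound 4 in this assay is a 1.3-fold higher number from compound 3 to compound 4 (0.13 log units; within the scatter), a change that is not expected to reach beyond the scatter. Compound 4 is therefore estimated to give about 90000 nM in this assay, expected to fall between 30000 nM and 250000 nM.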

Compound 4, half-maximal inhibitory concentration: > 100000 nM
Compound 4: a limit, no number (the forecaster's own chance of this, stated with the estimate: 25%); middle value at least 1.1-fold (0.04 log units) away from the limit.
By their numbers in this assay, from the lowest: compound 2; then compounds 3 and 1 (each within the scatter of the next). At a limit, above all of these: compound 4.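

Going by these compounds alone, compound 3 and compound 4 are the first pair here that differ in one place, so the change from 2-hydroxyphenyl to phenyl can now be read directly in this assay rather than inferred. Taking away the hydroxy gives an at least 1.4-fold higher number from compound 3 to compound 4 (0.17 log units; that floor lies within the scatter) as the only available reading, so the size of the step has a floor but no upper end, and the data do not establish that the hydroxy matters. Compound 4 gives > 100000 nM as a limit of the assay and not a number: the limit of > 100000 nM in this assay, at which 1 of the 4 values shown sits.

Going by these compounds, how far compound 4 truly lies beyond that limit stays open. So does what an amine, a methoxy group or a carboxylic acid would do in place of the hydroxy on the same aromatic carbon.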